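Anilino ring substituent change on the shared core

The source may hold more compounds than are shown below. What is called first, only, known or untested is meant among the compounds shown, and "the series" means these compounds.

Measured in a functional assay on HL-60 cells (Homo sapiens) for cytotoxicity, read by MTT assay, with a stated time of 48 h; a higher number here means a weaker inhibitor, a lower number a stronger inhibitor:
compound 1 `Fc1cccc(-c2nc(Nc3ccccc3)c3cc(F)ccc3n2)c1`: 48300 nM
compound 2 `Fc1cccc(-c2nc(Nc3ccccc3Cl)c3cc(F)ccc3n2)c1`: > 50000 nM

Compound 1 sits at a weak value. For compound 2 the figure > 50000 nM is a limit of this assay, not a number; (the limit of > 50000 nM in this assay, at which 1 of the 2 values shown sits). For the measured compounds named here, the only step measured is an at least 1.0-fold higher number from compound 1 to compound 2 (0.01 log units; that floor lies within the scatter).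

Compound 3 `Fc1cccc(-c2nc(Nc3ccc(Br)cc3)c3cc(F)ccc3n2)c1` differs from compound 2 by 4-bromophenyl in place of 2-chlorophenyl on a nitrogen on an aromatic ring. Going by the values given here, only the step from compound 1 to compound 2 bears on this change, and it is within the scatter and ends at a limit, so no step beyond the scatter is expected in this assay. Compound 3 is expected near 55000 nM, between 25000 nM and 120000 nM. This estimate means an expected step that the limit leaves unreadable from compound 2 to compound 3.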

Compound 3, half-maximal inhibitory concentration: > 50000 nM
Compound 3 gave a limit, no number; the forecaster's own chance of this, stated with the estimate: 55%; the middle value does not contradict the limit.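

In this assay compound 3 gives > 50000 nM, which is a limit and not a number. Bromo in place of hydrogen gives an at least 1.0-fold higher number from compound 1 to compound 3 (0.01 log units; that floor lies within the scatter), so 4-bromophenyl, like 2-chlorophenyl, shows no step beyond the scatter from the unsubstituted anilino ring. The step between the two limit values cannot be read, and the limit now caps both halogen-bearing compounds: the limit of > 50000 nM in this assay, at which 2 of the 3 values shown sit.

Open, from the compounds shown here alone, is whether a non-halogen group on this ring, such as an amine or a carboxylic acid, gives a number rather than a limit in this assay.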